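A few compounds are considered here, and "the series" means these few. Any claim that something is new, unique, unknown or untested is made for them only; others in the source may bear on it.

Measured compounds:
compound 1 `COc1cc2nc(SCC(=O)Nc3cc([N+](=O)[O-])ccc3F)nc(Nc3c(Cl)cc(/C=C/C#N)cc3Cl)c2cc1OC` with > 199000 nM
compound 2 `COc1cc2nc(SCC(=O)Nc3ccc(C)cc3)nc(Nc3c(Cl)cc(/C=C/C#N)cc3Cl)c2cc1OC` with 2540 nM
compound 3 `COc1cc2nc([S+]([O-])CC(=O)Nc3cc([N+](=O)[O-])ccc3F)nc(Nc3c(Cl)cc(/C=C/C#N)cc3Cl)c2cc1OC` with > 194000 nM

In an ADME assay on MT4 cells (Homo sapiens) for cytotoxicity, read by MTT assay, with a stated time of 5 days (a higher number here means that more compound is tolerated, a lower number that less compound is tolerated), compound 1 gives only a limit, > 199000 nM (the limit of > 199000 nM in this assay, at which 1 of the 3 values shown sits). Compound 2 gives a number, 2540 nM. The step between them, an at least 78-fold lower number from compound 1 to compound 2 (1.89 log units; beyond the scatter), comes from 4-methylphenyl in place of 2-fluoro-5-nitrophenyl on an amide-type nitrogen. Compound 3 likewise gives only a limit, > 194000 nM (the limit of > 194000 nM in this assay, at which 1 of the 3 values shown sits). How the core of compound 3 differs from the core of compound 1 is not broken down here.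

Compound 4 `COc1cc2nc([S+]([O-])CC(=O)Nc3ccc(C)cc3)nc(Nc3c(Cl)cc(/C=C/C#N)cc3Cl)c2cc1OC` is not yet measured. It differs from compound 3 by 4-methylphenyl in place of 2-fluoro-5-nitrophenyl on an amide-type nitrogen, the same change in the same place as that from compound 1 to compound 2. Compound 3 sits at a limit. The step of an at least 64-fold lower number from compound 3 to compound 4 (1.81 log units; beyond the scatter) is expected to be of similar size to the earlier one, which rests on compound 2 giving 2540 nM. Compound 4 is therefore estimated at 3000 nM in this assay, between 800 nM and 20000 nM.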

Compound 4, half-maximal cytotoxic concentration: 32200 nM
Compound 4: middle estimate off by 11-fold (1.03 log units), on the low side; the measured number lies above the stated range.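

In this assay, placing 4-methylphenyl in place of 2-fluoro-5-nitrophenyl on an amide-type nitrogen gives an at least 6.0-fold lower number from compound 3 to compound 4 (0.77 log units; beyond the scatter), so the direction of the earlier step recurs on the second core. Both steps start from a limit, so each gives only a minimum size, and the two sizes cannot be ranked: the same change on two cores in this assay, an at least 78-fold lower number (1.89 log units; beyond the scatter) from compound 1 to compound 2 and an at least 6.0-fold lower number (0.77 log units; beyond the scatter) from compound 3 to compound 4; the limit leaves it open whether they differ This shows that the direction held on the two cores shown, but it does not show that the size of the change carries over, or that the change would behave the same way on any further core.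

The compounds shown leave open whether the 2-fluoro-5-nitrophenyl effect belongs to the fluoro group, the nitro group or both, which a phenyl carrying only one of them could address. They also leave open how a plain phenyl or a 4-methoxyphenyl on the same nitrogen would read, and what a sulfone at the sulfur would do.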